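Bromophenyl in Place of Thiophene on a Shared Core

This account rests on a few compounds, and the source may have more. Where it says the series, first, only, none or still open, it means among the compounds named here.

Compound 1 `O=C(NCc1cccs1)N1C(=O)c2ccccc2S1(=O)=O` carries a thiophen-2-yl on a saturated chain carbon bound to an amide-type nitrogen. In a physicochemical assay for pharmacokinetics (on this read-out lower numbers stand for a shorter-lived compound and higher numbers for a longer-lived compound), compound 1 gives > 166 h, which is a limit of the measurement and not a number. Compound 2 `O=C(NCc1ccc(C(F)(F)F)cc1)N1C(=O)c2ccccc2S1(=O)=O` in this assay gives > 166 h, likewise a limit. Compound 3 `O=C(CCc1ccccc1)N1C(=O)c2ccccc2S1(=O)=O` in this assay gives > 166 h, again a limit. Compound 1 therefore stands where every other measured compound stands, at the limit of > 166 h in this assay, at which 3 of the 3 values shown sit, and no order among the three can be drawn from these values. For the measured compounds named here, no two measured compounds differ in a single place, so no measured step exists.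

Compound 4 `O=C(NCc1cccc(Br)c1)N1C(=O)c2ccccc2S1(=O)=O` has not yet been measured in this assay. It differs from compound 1 by 3-bromophenyl in place of thiophen-2-yl on a saturated chain carbon bound to an amide-type nitrogen. The step that the limit leaves unreadable from compound 1 to compound 4 is expected to be none beyond the scatter because the limit of > 166 h in this assay, at which 3 of the 3 values shown sit, places all measured values at the same limit. Compound 4 is thus expected to give about 200 h in this assay, within 100 h to 400 h, and most likely to be reported again as a limit.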

Compound 4, half-life: > 166 h
Compound 4 ended at the assay's limit; the forecaster's own chance of this, stated with the estimate: 85%; the middle value lies beyond the limit too.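

In this assay, for the compounds shown here, compound 1 and compound 4 both end at a limit and not at a number, so no step between them can be read: the limit of > 166 h in this assay, at which 4 of the 4 values shown sit.

The compounds shown leave open what the actual half-life of any of them is, and whether 3-bromophenyl in place of thiophen-2-yl shifts it at all.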